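The source may hold more compounds than are shown below. What is called first, only, known or untested is meant among the compounds shown, and "the series" means these compounds.

Going by the values given here, in a functional assay on PC-3 cells (Homo sapiens) for antiproliferative activity, read by MTT assay, with a stated time of 24 h (a lower number here means a stronger inhibitor, a higher number a weaker inhibitor), compound 1 (`CCn1c(C(=O)N[C@H](CO)CCO)ccc1C(CC)(CC)c1ccc(OCS(=O)(=O)c2ccccc2)c(C)c1`) gives 12100 nM and compound 2 (`CCn1c(C(=O)N[C@@H](C)C(=O)O)ccc1C(CC)(CC)c1ccc(OCS(=O)(=O)c2ccccc2)c(C)c1`) gives 16800 nM as its read-out, so compound 2 sits level with its only measured neighbour, within the scatter. That one measured step (a 1.4-fold higher number from compound 1 to compound 2 (0.14 log units; within the scatter)) puts 1-carboxyethyl in place of 3-hydroxy-1-(hydroxymethyl)propyl on an amide-type nitrogen. It says nothing direct about configuration.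

Compound 3 (`CCn1c(C(=O)N[C@H](C)C(=O)O)ccc1C(CC)(CC)c1ccc(OCS(=O)(=O)c2ccccc2)c(C)c1`) has the same atoms and bonds as compound 2 (the two compounds have the same atoms and bonds and differ only in configuration as drawn: 1 of 1 stereo elements differ; a stereocentre at a saturated chain carbon is drawn S in compound 2 and R in compound 3): a stereocentre at a saturated chain carbon is drawn S in compound 2 and R in compound 3. Among the compounds with values here, no measured pair tests such a change, so the evidence is indirect and the range has to stay wide. Within the data shown here, the expectation rests on compound 2 at 16800 nM and on the small size of the one measured step (a 1.4-fold higher number from compound 1 to compound 2 (0.14 log units; within the scatter)) in the same side chain region. The expected step (a 1.0-fold higher number from compound 2 to compound 3 (0.01 log units; within the scatter)) is therefore none beyond the scatter, in neither direction. Compound 3 is estimated at 17000 nM in this assay with an expected range from 8000 nM to 36000 nM as the working span.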

Compound 3, half-maximal inhibitory concentration: 20100 nM
Beside the measured number, compound 3's estimate is 1.2-fold (0.07 log units) below it; low and high end bracket the measured number.
By their numbers in this assay, from the lowest: compounds 1, 2 and 3 (each within the scatter of the next).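

In this assay, going by these compounds alone, the change of configuration at the saturated chain carbon of the 1-carboxyethyl group gives a 1.2-fold higher number from compound 2 to compound 3 (0.08 log units; within the scatter), which is the first direct reading on configuration at this position and shows no difference beyond the scatter. The exchange of 3-hydroxy-1-(hydroxymethyl)propyl for 1-carboxyethyl on the amide-type nitrogen, earlier read only with the S form in compound 2, now also reads with the R form as a 1.7-fold higher number from compound 1 to compound 3 (0.22 log units; within the scatter), so with either drawn configuration this exchange stays within the scatter. The comparison of the two 1-carboxyethyl compounds isolates a single variable, with no other structural change to account for: the fact that compounds 2 and 3 differ only in the configuration as drawn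

All three compounds carry a hydroxy or carboxylic acid substituent on this nitrogen and lie within the scatter of one another, so no change at this position has yet moved the read-out in this assay. Still open, from the compounds shown here alone, is whether an amine or a longer chain on the amide-type nitrogen would give a step beyond the scatter, and whether configuration would matter in such a side chain.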